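Swapping the Aminobutyl Chain for Isopropyl: An Expected Drop

The compounds below may be only part of what the source reports. "The series", "measured", "known", "first", "only" and "open" are said of these compounds alone.

Of the compounds shown here, three sharing one core have been tested in a functional assay on the whole organism (Tail, strain ICR) with Mus musculus as the target, in the tail flick test, with a stated time of 60 min, at a dose of 25 umol/kg by the oral route; a higher number here means a stronger effect of the compound at the dose given, a lower number a weaker effect. Compound 1 `O=C(CN(c1nc(Cl)nc2[nH]cnc12)C1CC1)N[C@@H](CO)C(=O)O` gives 39.8%. Compound 2 `O=C(O)CC[C@H](NC(=O)CN(c1nc(Cl)nc2[nH]cnc12)C1CC1)C(=O)O` gives 33.3%. Compound 3 `NCCCC[C@H](NC(=O)CN(c1nc(Cl)nc2[nH]cnc12)C1CC1)C(=O)O` gives 53.8%, the highest of the three, and since its gaps to compound 1 and to compound 2 are each beyond the scatter, compound 3 is the most active of the measured set.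

Compound 4 `CC(C)[C@H](NC(=O)CN(c1nc(Cl)nc2[nH]cnc12)C1CC1)C(=O)O` has not yet been measured in this assay. It differs from compound 3 in one place: isopropyl in place of 4-aminobutyl on a saturated chain carbon bound to an amide-type nitrogen and a carbonyl carbon.

For the measured compounds named here, two measured steps bear on this change, as both end at compound 3 by bringing in an amine-bearing chain: a number 14 percentage points higher from compound 1 to compound 3 (beyond the scatter) and a number 20.5 percentage points higher from compound 2 to compound 3 (beyond the scatter). A further step, a number 6.5 percentage points lower from compound 1 to compound 2 (within the scatter), shows little separation between the two compounds without such a chain. Going by the values given here, no measured pair matches a change to isopropyl directly, but compound 4 lacks the chain that both upward steps introduced, so a modest fall back toward the level of compound 1 and compound 2 seems the likeliest outcome. For compound 4 a modest drop is expected, a number 15.8 percentage points lower from compound 3 to compound 4 (beyond the scatter). Compound 4 is estimated to give 38%, with a range from 24% to 52%.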

Compound 4, a percentage reported as activity, at one dose (the size of the read-out at that dose, not a potency): 38.8%
Beside the measured number, compound 4's estimate is 0.8 percentage points below it; low and high end bracket the measured number.
By their numbers in this assay, from the lowest: compounds 2, 4 and 1 (each within the scatter of the next); then compound 3.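

In this assay, isopropyl in place of 4-aminobutyl on the saturated chain carbon bound to an amide-type nitrogen and a carbonyl carbon gives a clear fall (a number 15 percentage points lower from compound 3 to compound 4 (beyond the scatter)), so this position does not hold the level of compound 3 with just any small chain. Isopropyl, which has no hydrogen-bond donors or acceptors, also sits level with hydroxymethyl (a number 1 percentage points lower from compound 1 to compound 4 (within the scatter)) and with 2-carboxyethyl (a number 5.5 percentage points higher from compound 2 to compound 4 (within the scatter)), so among these four compounds only the 4-aminobutyl chain stands apart. Nothing measured here gives a reason for this difference.

The compounds shown leave open whether the amine or the length of the chain sets compound 3 apart. A plain butyl chain without the amine and a shorter 2-aminoethyl chain would separate the two.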